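The source may hold more compounds than are shown below. What is called first, only, known or untested is meant among the compounds shown, and "the series" means these compounds.

Measured compounds:
- compound 1, `COc1ccc(-c2cc(/C=C/C(=O)c3ccc(N)cc3)[nH]n2)cc1`: 103%
- compound 2, `COc1cc(-c2cc(/C=C/C(=O)c3ccc(N)cc3)[nH]n2)cc(OC)c1OC`: 98%

Both values were obtained in a functional assay on SK-OV-3 cells (Homo sapiens) for cytotoxicity, read by sulforhodamine B assay, with a stated time of 48 h, tested at 0.1 uM; on this read-out higher numbers stand for a weaker effect at the one concentration tested and lower numbers for a stronger effect. Compound 2 gives 98% in this assay.

Correction, without the short-name typing: in this assay compound 2 gives 98%, and in this assay compound 1 gives 103%; the two numbers lie within the scatter of each other, so neither is set apart, and both stand near the level of untreated cells at the concentration used.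

Compound 3, `COc1cc(-c2cc(/C=C/C(=O)c3ccc(Cl)c(Cl)c3)[nH]n2)cc(OC)c1OC`, has not yet been measured. It differs from compound 2 in one place: 3,4-dichlorophenyl in place of 4-aminophenyl on a carbonyl carbon. Among the compounds with values here, no pair of measured compounds shows the effect of such a change, so there is no step to lean on. Since both measured compounds sit at the top of the scale, a step from compound 2 to compound 3 of any size beyond the scatter in either direction is not expected; the number for compound 3 is expected to stay near full activity, with a step of a number 3 percentage points lower from compound 2 to compound 3 (within the scatter). The estimate for compound 3 in this assay is 95%, with a range from 80% to 110%.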

Compound 3, a percentage reported as activity, at one concentration (the size of the read-out at that concentration, not a potency): 104%
For compound 3 the middle estimate is 9 percentage points below the measured one, within the range that was stated.
By their numbers in this assay, from the lowest: compounds 2, 1 and 3 (each within the scatter of the next).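

In this assay, the first change read at this carbonyl carbon, 3,4-dichlorophenyl in place of 4-aminophenyl, comes to a number 6 percentage points higher from compound 2 to compound 3 (within the scatter). The hydrogen-bond donor and acceptor counted on 4-aminophenyl are absent from 3,4-dichlorophenyl, yet at the one concentration tested this read-out does not separate the two groups, so this position shows no sensitivity to this change under these conditions. No measured property of these compounds bears on this result.

Still open, as far as these compounds go, is whether the same change would separate the two groups at concentrations where the series gives a clear effect in this assay. Also open, from the compounds shown here alone, is how a carboxylic acid, a morpholine or a pyridine on this carbonyl carbon would read, and whether 3,4-dichlorophenyl would read the same on the core of compound 1.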